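Trading 4-Fluorophenyl for 3-Methylphenyl

The source may hold more compounds than are shown below. What is called first, only, known or untested is meant among the compounds shown, and "the series" means these compounds.

Measured so far in a functional assay on A-431 cells (Homo sapiens) for antiproliferative activity, read by MTT assay, with a stated time of 72 h; a lower number here means a stronger inhibitor, a higher number a weaker inhibitor:
compound 1 `COc1cc2ncnc(Nc3ccc(Cl)c(C(F)(F)F)c3)c2cc1OCCCCC(=O)Nc1ccc(S(N)(=O)=O)cc1` gives 3910 nM;
compound 2 `COc1cc2ncnc(Nc3ccc(F)cc3)c2cc1OCCCCC(=O)Nc1ccc(S(N)(=O)=O)cc1` gives 18600 nM;
compound 3 `COc1cc2ncnc(Nc3ccc(F)c(Br)c3)c2cc1OCCCCC(=O)Nc1ccc(S(N)(=O)=O)cc1` gives 8020 nM.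

Compound 2 holds the highest number of the three, so on these figures it is the weakest inhibitor; compound 3 lies nearer to it and compound 1 furthest away. The three share one core and differ only in the ring attached to a nitrogen on an aromatic ring. Compound 4 `COc1cc2ncnc(Nc3cccc(C)c3)c2cc1OCCCCC(=O)Nc1ccc(S(N)(=O)=O)cc1` has not yet been tested; set against compound 2 the change is 3-methylphenyl in place of 4-fluorophenyl on a nitrogen on an aromatic ring. Among the measured compounds shown here, three measured steps bear on it. a 4.8-fold higher number from compound 1 to compound 2 (0.68 log units; beyond the scatter) and a 2.1-fold higher number from compound 1 to compound 3 (0.31 log units; beyond the scatter) show that the ring carrying more groups went with the stronger inhibitor, and a 2.3-fold lower number from compound 2 to compound 3 (0.37 log units; beyond the scatter) shows that putting bromo where hydrogen stood gave a modest gain. A 3-methylphenyl likewise carries one group on the ring, so a modest step of similar size is expected, a 1.9-fold lower number from compound 2 to compound 4 (0.27 log units; within the scatter). Compound 4 is therefore estimated at 10000 nM, with a range from 4000 nM to 25000 nM.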

Compound 4, half-maximal inhibitory concentration: 7460 nM
Compound 4: middle estimate off by 1.3-fold (0.13 log units), on the high side, and the stated range covers the measured number.
By their numbers in this assay, from the lowest: compounds 1, 4 and 3 (each within the scatter of the next, the first and the last beyond it); then compound 2.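

In this assay, the swap gives a 2.5-fold lower number from compound 2 to compound 4 (0.40 log units; beyond the scatter), so a ring with no halogen at all can beat the 4-fluorophenyl ring, and it does so with no change in the count of heavy atoms. Compound 4 also carries fewer groups on its ring than the rings of compounds 1 and 3, yet the steps of a 1.1-fold lower number from compound 3 to compound 4 (0.03 log units; within the scatter) and a 1.9-fold higher number from compound 1 to compound 4 (0.28 log units; within the scatter) separate it from neither, so more groups on the ring are not needed to reach this level. Nothing shown here gives a reason for the gain.

This one swap removes a fluoro group and adds a methyl group in a single move, so the compounds shown cannot say which of the two matters. A plain phenyl or a 4-methylphenyl on the same nitrogen would pull the two apart, and a 3-methoxyphenyl would test other groups in the methyl group's place.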